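Swapping the amine on the shared core of two benzamide analogues

The compounds below may be only part of what the source reports. "The series", "measured", "known", "first", "only" and "open" are said of these compounds alone.

Measured so far:
Compound 1 `CC1CCN(c2nc(Cl)nc3c2ncn3Cc2ccc(/C=C/C(=O)Nc3ccccc3N)cc2)CC1` — 8.73%
Compound 2 `Nc1ccccc1NC(=O)c1ccc(Cn2cnc3c(Nc4cccc(OC(F)(F)F)c4)nc(Cl)nc32)cc1` — 1.88%

Of the compounds shown here, two have been tested in a functional assay on HepG2 cells (Homo sapiens) for antiproliferative activity, read by CCK-8 assay, with a stated time of 72 h, tested at 2 uM; on this read-out higher numbers stand for a stronger effect at the one concentration tested and lower numbers for a weaker effect. Compound 1 gives 8.73% in this assay, and compound 2 gives 1.88%. The gap between these two numbers lies within the usual scatter of repeated measurements, so neither compound can be said to act differently from the other; compound 2 simply gives a number at the lower edge of what has been seen, with compound 1 within scatter of it.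

Compound 3 `CC1CCN(c2nc(Cl)nc3c2ncn3Cc2ccc(C(=O)Nc3ccccc3N)cc2)CC1` has not yet been measured. It differs from compound 2 in one place: 4-methylpiperidin-1-yl in place of (3-(trifluoromethoxy)phenyl)amino on an aromatic carbon. Within the data shown here, this is the same 4-methylpiperidin-1-yl group that compound 1 carries on its core, though compound 1 and compound 3 otherwise differ in the linker and no step between them is given.

Since both measured values sit close together and low, the step of a number 4.1 percentage points higher from compound 2 to compound 3 (within the scatter) is expected to be small, with no change beyond the scatter, if anything pointing slightly upward toward the value of compound 1. Compound 3 is therefore estimated to give 6%, with a range from 0% to 18%.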

Compound 3, a percentage reported as inhibition, at one concentration (the size of the read-out at that concentration, not a potency): 1.22%
The estimate for compound 3 lay 4.8 percentage points above the measured number, within the range that was stated.
By their numbers in this assay, from the lowest: compounds 3, 2 and 1 (each within the scatter of the next).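

In this assay, 4-methylpiperidin-1-yl in place of (3-(trifluoromethoxy)phenyl)amino on an aromatic carbon of the shared core gives a number 0.7 percentage points lower from compound 2 to compound 3 (within the scatter), so this exchange of an aromatic amine for a non-aromatic ring, with five fewer heavy atoms, leaves no difference that the read-out can resolve. The second change, (2-aminophenyl)carbamoyl in place of 2-((2-aminophenyl)carbamoyl)ethenyl, gives a number 7.5 percentage points lower from compound 1 to compound 3 (within the scatter), so with 4-methylpiperidin-1-yl held in place, removing the ethenyl link also separates nothing in this assay. No measurement of any other property bears on these two steps, and nothing here can explain them.

On these data alone, what remains open is whether any group at this aromatic carbon, such as a primary amine, a morpholine ring or a carboxylic acid, would move the number beyond the scatter, and whether a longer chain in place of the ethenyl link would do so. With only one concentration read, the compounds shown also leave open whether these changes would separate at other concentrations or in other cells.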